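Swapping the aryl group on a hydrazone: compound 4

The source may hold more compounds than are shown below. What is called first, only, known or untested is meant among the compounds shown, and "the series" means these compounds.

Measured compounds in a functional assay on SW 1116 cells (Homo sapiens) for cytotoxicity, read by MTT assay, with a stated time of 48 h; on this read-out higher numbers stand for weaker inhibition and lower numbers for stronger inhibition:
- Compound 1 `NNC(=O)CSc1nnc(-c2ccncc2)o1` gives 3260 nM
- Compound 2 `O=C(CSc1nnc(-c2ccncc2)o1)N/N=C/c1cccc(C(F)(F)F)c1` gives 14900 nM
- Compound 3 `COc1cccc(/C=N/NC(=O)CSc2nnc(-c3ccncc3)o2)c1` gives 16500 nM

Compound 3 stands at the highest of the three numbers. Its nearest neighbour is compound 2, and the step of a 1.1-fold higher number from compound 2 to compound 3 (0.04 log units; within the scatter) shows that replacing trifluoromethyl with methoxy on the aromatic ring moved the number only within the scatter. Compound 1, which carries no aryl hydrazone at all, sits furthest away with a lower number.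

Compound 4 `O=C(CSc1nnc(-c2ccncc2)o1)N/N=C/c1cc(Cl)cc(Cl)c1O` has not yet been measured. Compared with compound 3, the change is 3,5-dichloro-2-hydroxyphenyl in place of 3-methoxyphenyl on a carbon with a double bond to nitrogen. Going by the values given here, the only measured step that bears on this is the one from compound 2 to compound 3, where exchanging one substituent on the same aromatic ring gave no shift beyond the scatter. Compound 4 brings a new pattern of groups, including a hydrogen-bond donor, so the precedent is only partial. For compound 4 the step of a 1.4-fold lower number from compound 3 to compound 4 (0.14 log units; within the scatter) is expected to stay small, with a number estimated at 12000 nM, within 4000 nM to 35000 nM.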

Compound 4, half-maximal inhibitory concentration: 5030 nM
The estimate for compound 4 lay 2.4-fold (0.38 log units) above the measured number, and the stated range covers the measured number.
By their numbers in this assay, from the lowest: compounds 1 and 4 (each within the scatter of the next); then compounds 2 and 3 (each within the scatter of the next).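

In this assay the group on the carbon with a double bond to nitrogen proves able to move the number: 3,5-dichloro-2-hydroxyphenyl in place of 3-methoxyphenyl gives a 3.3-fold lower number from compound 3 to compound 4 (0.52 log units; beyond the scatter) and so makes a modest step beyond the scatter. Going by these compounds alone, the earlier exchange of one substituent on that ring, a 1.1-fold higher number from compound 2 to compound 3 (0.04 log units; within the scatter), stayed within the scatter, so this is the first sign that the aryl group on the hydrazone can matter. The swap alters several things at once, and nothing available bears on why the number moved.

The compounds shown leave open whether the hydroxy group, the chlorines or the loss of methoxy carries the step. They also leave open how an amine or a carboxylic acid on the same ring would read.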